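The source may report more compounds than this note shows. Statements on the series, on what has been measured and on what is new or still open speak of the compounds shown alone.

Measured compounds in the series so far:

compound 1 `Cc1cc(NC(=O)Nc2ccccc2F)c2ccccc2n1` — in an ADME assay on Raji cells (Homo sapiens) for cytotoxicity, with a stated time of 72 h (a higher number here means that more compound is needed for the effect, a lower number that less compound is needed), compound 1 gives > 25000 nM, which is a limit of the assay and not a number.
compound 2 `CSc1ccccc1NC(=O)Nc1cc(C)nc2ccccc12` — in this assay compound 2 gives > 25000 nM, again a limit of the assay.
compound 3 `Cc1cc(NC(=O)Nc2ccccc2C(N)=O)c2ccccc2n1` — in this assay compound 3 gives > 25000 nM, likewise a limit of the assay.

Compound 3 therefore stands only as a limit, and so do the two other values shown: every value sits at the limit of > 25000 nM in this assay, at which 3 of the 3 values shown sit. The three steps that connect the measured compounds, a step that the two limits leave unreadable from compound 1 to compound 2, a step that the two limits leave unreadable from compound 1 to compound 3 and a step that the two limits leave unreadable from compound 2 to compound 3, are all unreadable for this reason; none of them gives a size or a direction.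

Next in line is compound 4 `Cc1cc(NC(=O)Nc2ccccc2[N+](=O)[O-])c2ccccc2n1`. Relative to compound 3 the change is nitro in place of carbamoyl on an aromatic carbon. Going by the values given here, the steps that bear on it are those that alter the same aromatic carbon, from compound 1 to compound 3 and from compound 2 to compound 3, but both are hidden by the limit and give no readable size. With nothing in the series yet rising above the limit, no step beyond the scatter is expected in this assay; the step from compound 3 to compound 4 is estimated as a step that the limit leaves unreadable from compound 3 to compound 4. Compound 4 is accordingly expected to give 30000 nM in this assay, with a range from 10000 nM to 100000 nM, most likely reported only as a limit again.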

Compound 4, half-maximal effective concentration: > 25000 nM
Compound 4 ended at the assay's limit; the forecaster's own chance of this, stated with the estimate: 80%; the middle value is on the limit's open side.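

Compound 4 stands only as a limit of the assay, like compound 1, compound 2 and compound 3, so none of the steps to compound 4 can be read in this assay: the limit of > 25000 nM in this assay, at which 4 of the 4 values shown sit. The compounds shown leave open how the fluoro, methylsulfanyl, carbamoyl and nitro compounds rank, and whether any change in the series gives a readable value.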